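Swapping Phenyl for Thiophene on a Nucleoside Core

The source may hold more compounds than are shown below. What is called first, only, known or untested is meant among the compounds shown, and "the series" means these compounds.

Compound 1 `Cc1nc(N)c2c(-c3ccccc3)cn([C@@H]3O[C@H](CO)[C@@H](O)[C@H]3O)c2n1` carries a phenyl group on the five-membered ring of its fused core. In a functional assay on CEM-DNR-bulk cells (Homo sapiens), read by MTT assay, with a stated time of 72 h (on this read-out higher numbers stand for weaker inhibition and lower numbers for stronger inhibition), compound 1 gives > 20000 nM, which is a limit of the assay rather than a number. Two related compounds help to read the change. Compound 2 `C#Cc1cn([C@@H]2O[C@H](CO)[C@@H](O)[C@H]2O)c2ncnc(NC)c12` bears an ethynyl group at the same position and gives 18500 nM in this assay. Compound 3 `CNc1ncnc2c1c(-c1ccsc1)cn2[C@@H]1O[C@H](CO)[C@@H](O)[C@H]1O` bears a thiophen-3-yl group instead; in this assay compound 3 gives > 20000 nM, again a limit and not a number. The step of an at least 1.0-fold higher number from compound 2 to compound 3 (0.03 log units; that floor lies within the scatter) is therefore only a floor, and it lies within the scatter. The unmeasured compound 4 `Cc1nc(N)c2c(-c3ccsc3)cn([C@@H]3O[C@H](CO)[C@@H](O)[C@H]3O)c2n1` differs from compound 1 by thiophen-3-yl in place of phenyl on an aromatic carbon, and this is the same thiophen-3-yl group that sits on compound 3. Among the compounds with values here, the one measured step that bears on it shows no movement beyond the scatter, and the limit of > 20000 nM in this assay, at which 2 of the 3 values shown sit, means two of the three values here are already limits. The expected step that the limit leaves unreadable from compound 1 to compound 4 is therefore none beyond the scatter, most likely ending again at a limit. Compound 4 is estimated at 25000 nM, with a range from 12000 nM to 60000 nM.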

Compound 4, half-maximal inhibitory concentration: > 20000 nM
Compound 4: only a limit was reported (the forecaster's own chance of this, stated with the estimate: 75%); the middle value lies beyond the limit too.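

Swapping phenyl for thiophen-3-yl from compound 1 to compound 4 gives no readable step, because both compounds report only a limit and not a number: the limit of > 20000 nM in this assay, at which 3 of the 4 values shown sit.

The compounds shown leave open whether phenyl and thiophen-3-yl differ at all on the core of compound 1, and which change to that core would give a measured number.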